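The source may report more compounds than this note shows. Statements on the series, on what has been measured and on what is new or still open speak of the compounds shown alone.

Compound 3 `COc1ccc(C2=CCN(S(=O)(=O)N3CCCC[C@@H]3C(=O)NO)CC2)cc1` gives 15000 nM in a functional assay on MONO-MAC-6 cells (Homo sapiens) for inhibition (on this read-out higher numbers stand for weaker inhibition and lower numbers for stronger inhibition), the highest of the three numbers seen, while compound 2 `O=C(NO)[C@H]1CCCCN1S(=O)(=O)N1CC=C(c2ccc(F)cc2)CC1` gives 300 nM and compound 1 `O=C(NO)[C@H]1CCCCN1S(=O)(=O)N1CC=C(c2ccccc2)CC1` gives 240 nM. The steps of a 63-fold higher number from compound 1 to compound 3 (1.80 log units; beyond the scatter) and a 50-fold higher number from compound 2 to compound 3 (1.70 log units; beyond the scatter) are large, whereas a 1.3-fold higher number from compound 1 to compound 2 (0.10 log units; within the scatter) stays within the scatter. Compound 4 `O=C(NO)[C@H]1CCCCN1S(=O)(=O)N1CC=C(c2ccc(-c3ccccc3)cc2)CC1` differs from compound 3 by phenyl in place of methoxy on an aromatic carbon. Within the data shown here, no measured step involves a phenyl at this place; the two large steps show only that methoxy there carries a far higher number than hydrogen or fluoro, and a different group need not behave the same way. The expectation for compound 4 is therefore uncertain, but a step of a 3.8-fold lower number from compound 3 to compound 4 (0.57 log units; beyond the scatter) is expected. Compound 4 is estimated at 4000 nM, within a range from 400 nM to 40000 nM.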

Compound 4, half-maximal inhibitory concentration: 19000 nM
Beside the measured number, compound 4's estimate is 4.8-fold (0.68 log units) below it, and the stated range covers the measured number.
By their numbers in this assay, from the lowest: compounds 1 and 2 (each within the scatter of the next); then compounds 3 and 4 (each within the scatter of the next).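

With a 79-fold higher number from compound 1 to compound 4 (1.90 log units; beyond the scatter) and a 63-fold higher number from compound 2 to compound 4 (1.80 log units; beyond the scatter) in this assay, phenyl becomes a second group at this aromatic carbon that sits far above hydrogen and fluoro, so the large rise is not confined to methoxy. The exchange itself (a 1.3-fold higher number from compound 3 to compound 4 (0.10 log units; within the scatter)) separates the two groups in no way, although phenyl enters with more heavy atoms, a ring and no hydrogen-bond acceptor. The compounds shown leave open whether an amine, a carboxylic acid or a methyl at this place would stay near compound 1 or rise to the level of compound 3. Nothing available here explains the shared rise with methoxy and phenyl.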